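Isobutyl to cyclobutyl on the amide nitrogen of compound 1

The compounds below may be only part of what the source reports. "The series", "measured", "known", "first", "only" and "open" are said of these compounds alone.

Compound 1 `CNC(=O)c1cc(C(=O)NCC(C)C)cn(Cc2ccccc2)c1=O` stands at the top of the three measured values in a physicochemical assay for lipophilicity, at pH 7.4 (a higher number here means a more lipophilic compound, a lower number a more polar compound), where compound 1 gives 4.3. Compound 2 `CCNC(=O)c1cccn(Cc2ccccc2)c1=O` comes nearest to it, and in this assay compound 2 gives 3.7, a gap beyond the scatter. Compound 3 `CNC(=O)c1cc(C(=O)NC2CC2)cn(CC2CCOCC2)c1=O` lies furthest away; in this assay compound 3 gives 1.5, again a gap beyond the scatter. Compound 4 `CNC(=O)c1cc(C(=O)NC2CCC2)cn(Cc2ccccc2)c1=O` has not yet been measured. It differs from compound 1 in one place: cyclobutyl in place of isobutyl on an amide-type nitrogen. For the measured compounds named here, no measured pair shows this kind of change, so its effect cannot be read from the three compounds already measured. A small downward step from compound 1 to compound 4 in this assay is expected, estimated as a number 0.40 log units lower from compound 1 to compound 4 (beyond the scatter), which may or may not reach beyond the scatter. On that basis compound 4 is estimated at 3.9 in this assay, with a range from 3.4 to 4.4.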

Compound 4, distribution coefficient: 3.8
The estimate for compound 4 lay 0.10 log units above the measured number; the range from low to high includes it.
By their numbers in this assay, from the lowest: compound 3; then compounds 2 and 4 (each within the scatter of the next); then compound 1.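

For the compounds shown here, until now no two measured compounds differed in one place, so this pair gives the only direct reading at this amide-type nitrogen. In this assay, cyclobutyl in place of isobutyl gives a step of a number 0.50 log units lower from compound 1 to compound 4 (beyond the scatter), a modest change that lies beyond the scatter. Both groups have 4 heavy atoms, all carbon, and neither has hydrogen-bond donors or acceptors, so the two differ in the four-membered ring, but no measurement at hand explains why the number moves.

The compounds shown leave open whether the same exchange gives a similar step on a different core, since this pair is its only example. They also leave open how a longer chain, a cyclopentyl group or a chain bearing an amine on this nitrogen would read in this assay.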